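Swapping a Furan for a Trifluoromethylphenyl on the Amide Arm

This account rests on a few compounds, and the source may have more. Where it says the series, first, only, none or still open, it means among the compounds named here.

Compound 1 `N[C@H]1CC[C@H](Nc2c(C(=O)NCc3ccco3)nc(Br)c3cccnc23)CC1` has no number in a functional assay on MCF7 cells (Homo sapiens) for cytotoxicity, read by MTT assay, with a stated time of 72 h; a lower number here means a stronger inhibitor, a higher number a weaker inhibitor; its entry simply reads "not determined" (no result reported). Compound 2 `CC(C)(C)OC(=O)N1CCN(c2c(C(=O)NCc3ccc(F)cc3)nc(Br)c3cccnc23)CC1`, which carries a different group on the shared core, gives only a limit in this assay, namely > 10000 nM, and the limit of > 10000 nM in this assay, at which 1 of the 2 values shown sits, shows where that limit sits. Compound 3 `N[C@H]1CC[C@H](Nc2c(C(=O)NCc3cccc(C(F)(F)F)c3)nc(Br)c3cccnc23)CC1` differs from compound 1 by 3-(trifluoromethyl)phenyl in place of furan-2-yl on a saturated chain carbon bound to an amide-type nitrogen. With nothing measured for compound 1, the size of this step in this assay cannot be anchored, and a shift beyond the scatter in either direction would not surprise. Compound 3 is therefore expected, with wide uncertainty, to give about 5000 nM, somewhere between 500 nM and 50000 nM.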

Compound 3, half-maximal inhibitory concentration: 15000 nM
The estimate for compound 3 lay 3.0-fold (0.48 log units) below the measured number; low and high end bracket the measured number.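

Compound 1 has no number to set against compound 3, so no step can be read between them, and nothing shown accounts for the result of compound 3. The compounds shown leave open whether 3-(trifluoromethyl)benzyl in place of (furan-2-yl)methyl strengthens or weakens activity in this assay.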